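Permeability notes: aryl ether swap on the shared core

This account rests on a few compounds, and the source may have more. Where it says the series, first, only, none or still open, it means among the compounds named here.

Measured so far:
compound 1 `c1ccc(CCc2ccc3c(NCCCNCc4ccco4)ccnc3c2)cc1`: 23 10^-6 cm/s
compound 2 `COc1ccc(Oc2ccc3c(NCCCNCc4cc(F)ccc4OC)ccnc3c2)cc1`: 317 10^-6 cm/s

In an ADME assay for permeability, using PAMPA, with a stated time of 30 min, at pH 7.4 (on this read-out lower numbers stand for lower permeability and higher numbers for higher permeability), compound 2 carries the higher of the two numbers, with compound 1 well below it. Compound 3 `COc1ccc(F)cc1CNCCCNc1ccnc2cc(Oc3cccc(N(C)C)c3)ccc12` differs from compound 2 by 3-(dimethylamino)phenyl in place of 4-methoxyphenyl on an oxygen on an aromatic ring. Going by the values given here, no step between two measured compounds is available to guide this change. The expectation is a step, a 1.2-fold lower number from compound 2 to compound 3 (0.09 log units; within the scatter), that stays within the usual scatter, since compound 2 already gives 317 10^-6 cm/s and nothing in the measured pair points to a shift either way. Compound 3 is estimated at 260 10^-6 cm/s, within a range of 110 10^-6 cm/s to 520 10^-6 cm/s.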

Compound 3, apparent permeability: 317 10^-6 cm/s
Compound 3: middle estimate off by 1.2-fold (0.09 log units), on the low side; measured number inside the range.
By their numbers in this assay, from the lowest: compound 1; then compounds 2 and 3 (each within the scatter of the next).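

In this assay, the step of no change at the digits printed from compound 2 to compound 3 (within the scatter) comes with 3-(dimethylamino)phenyl in place of 4-methoxyphenyl on an oxygen on an aromatic ring. Going by these compounds alone, this is the first single-place step, and it shows that this position accepts this exchange of groups without a change beyond the scatter. No measurement available explains this outcome.

Still open, going by these compounds, is how this position responds to a carboxylic acid or a morpholine on the aromatic ring. The gap to compound 1 also remains unassigned, as that compound differs from the other two in more than one place.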